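A Hydroxyalkyl Chain on the Ring Nitrogen of Compound 3

This account rests on a few compounds, and the source may have more. Where it says the series, first, only, none or still open, it means among the compounds named here.

Compound 3 `O=C(Nc1cc(Oc2ccc(Nc3nccc4[nH]cc(-c5ccc(F)cc5)c(=O)c34)cc2F)ccn1)C1CC1` gives 25.5% in a functional assay on HT-29 cells (Homo sapiens) for antiproliferative activity, read by MTT assay, with a stated time of 72 h, tested at 10 uM; on this read-out higher numbers stand for more inhibition at the one concentration tested (going by the name of the read-out) and lower numbers for less inhibition. Among the three compounds measured, compound 3 stands second highest: the compound closest to it is compound 1 `CCn1cc(-c2ccc(F)cc2)c(=O)c2c(Nc3ccc(Oc4ccnc(NC(=O)C5CC5)c4)c(F)c3)nccc21`, which gives 15.8%, and the compound furthest from it is compound 2 `CC(=O)Nc1cc(Oc2ccc(Nc3nccc4[nH]cc(-c5ccc(F)cc5)c(=O)c34)cc2F)ccn1`, which gives 36.8%. The change now followed, (2-hydroxy-2-methylpropyl in place of hydrogen on an aromatic nitrogen), leads to compound 4 `CC(C)(O)Cn1cc(-c2ccc(F)cc2)c(=O)c2c(Nc3ccc(Oc4ccnc(NC(=O)C5CC5)c4)c(F)c3)nccc21`. Among the measured compounds shown here, one measured step bears on it directly: the same aromatic nitrogen is the place of a number 9.7 percentage points higher from compound 1 to compound 3 (within the scatter), so a substituent on that nitrogen has so far moved the number only within the scatter. The other step, a number 11.3 percentage points lower from compound 2 to compound 3 (beyond the scatter), concerns the carbonyl carbon and does not touch this position. The expectation is therefore a step of no size beyond the scatter, if anything a small lowering, estimated as a number 5.5 percentage points lower from compound 3 to compound 4 (within the scatter). Compound 4 is thus expected to give about 20%, within a range from 5% to 38%.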

Compound 4, a percentage reported as inhibition, at one concentration (the size of the read-out at that concentration, not a potency): -2.6%
The estimate for compound 4 lay 22.6 percentage points above the measured number, and the stated range ends above it.
By their numbers in this assay, from the lowest: compound 4; then compounds 1 and 3 (each within the scatter of the next); then compound 2.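

In this assay, 2-hydroxy-2-methylpropyl in place of hydrogen on the aromatic nitrogen gives a number 28.1 percentage points lower from compound 3 to compound 4 (beyond the scatter) and so shows that a substituent at this position can move the number beyond the scatter, which the ethyl step alone (a number 9.7 percentage points higher from compound 1 to compound 3 (within the scatter)) had not shown. The nature of the chain on this nitrogen also matters, since 1-hydroxy-1-methylethyl in place of methyl on the saturated chain carbon bound to it gives a number 18.4 percentage points lower from compound 1 to compound 4 (beyond the scatter) and separates two substituted compounds. No measurement at hand explains this drop.

The compounds shown leave open whether the hydroxyl or the branched carbon chain accounts for the step, a question that a plain 2-methylpropyl group on the same nitrogen would address. Going by these compounds, how an amine or a carboxylic acid at the end of such a chain would read also remains open.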